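Swapping fluoro for methoxy on the fused ring

A few compounds are considered here, and "the series" means these few. Any claim that something is new, unique, unknown or untested is made for them only; others in the source may bear on it.

Of the compounds shown here, three built on one shared core have been tested in a functional assay on PC-3 cells (Homo sapiens) for cytotoxicity, read by MTT assay, with a stated time of 72 h; a higher number here means a weaker inhibitor, a lower number a stronger inhibitor. Compound 1 `O=C(Nc1nc2ccc(F)cc2s1)c1cn(-c2ccccc2)nc1-c1ccccc1` gives 3250 nM. Compound 2 `COc1ccc2nc(NC(=O)c3cn(-c4ccccc4)nc3-c3ccccc3)sc2c1` gives 17500 nM. Compound 3 `O=C(Nc1nc2ccc(F)cc2s1)c1cn(-c2ccccc2)nc1-c1ccc(F)cc1` gives 5260 nM, which is the second highest of the three numbers: its nearest neighbour is compound 1, within the usual scatter, while compound 2 sits further away with the clearly higher number. Two single changes are already on record. Adding a fluoro on an aromatic carbon made little difference: a 1.6-fold higher number from compound 1 to compound 3 (0.21 log units; within the scatter). Replacing a fluoro by a methoxy on the fused ring made a modest but real difference: a 5.4-fold higher number from compound 1 to compound 2 (0.73 log units; beyond the scatter).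

Compound 4 `COc1ccc2nc(NC(=O)c3cn(-c4ccccc4)nc3-c3ccc(F)cc3)sc2c1` is the next member. It differs from compound 3 in one place: methoxy in place of fluoro on an aromatic carbon. This is the same swap, on the same part of the core, that separated compound 1 from compound 2, so that step is the one that bears on the outcome. A similar move is expected here, toward a higher number and thus a weaker inhibitor: a 5.1-fold higher number from compound 3 to compound 4 (0.71 log units; beyond the scatter). On that basis compound 4 is estimated at 27000 nM in this assay, within a range of 12000 nM to 60000 nM.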

Compound 4, half-maximal inhibitory concentration: 12800 nM
Compound 4: middle estimate off by 2.1-fold (0.32 log units), on the high side, and the stated range covers the measured number.
By their numbers in this assay, from the lowest: compounds 1 and 3 (each within the scatter of the next); then compounds 4 and 2 (each within the scatter of the next).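

The swap of fluoro for methoxy on this aromatic carbon of the fused ring now has a second reading in this assay, a 2.4-fold higher number from compound 3 to compound 4 (0.39 log units; beyond the scatter), so the move toward a higher number is no longer seen on one pair alone. The two readings point the same way, and their sizes do not differ by more than repeated measurements of two such steps would allow: the same change on two cores in this assay, a 5.4-fold higher number (0.73 log units; beyond the scatter) from compound 1 to compound 2 and a 2.4-fold higher number (0.39 log units; beyond the scatter) from compound 3 to compound 4, 2.2-fold (0.34 log units) apart, within the scatter of two such steps. The other change, fluoro in place of hydrogen on an aromatic carbon, also gains a second reading, a 1.4-fold lower number from compound 2 to compound 4 (0.14 log units; within the scatter), and on neither core does it move the number beyond the scatter: the same change on two cores in this assay, a 1.6-fold higher number (0.21 log units; within the scatter) from compound 1 to compound 3 and a 1.4-fold lower number (0.14 log units; within the scatter) from compound 2 to compound 4, 2.2-fold (0.34 log units) apart, within the scatter of two such steps.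

Only fluoro and methoxy appear on this aromatic carbon among the compounds shown, so how an amine, a carboxylic acid or a longer chain such as butoxy would read there remains open. As far as these compounds go, what lies behind the higher number with methoxy also remains open: all four compounds carry a single cell read-out, and that read-out does not say how the change acts.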